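The source may hold more compounds than are shown below. What is called first, only, known or untested is meant among the compounds shown, and "the series" means these compounds.

Three compounds have been measured in a functional assay on the whole organism (Tail, strain ICR) with Mus musculus as the target, in the tail flick test, with a stated time of 60 min, at a dose of 25 umol/kg by the oral route; on this read-out higher numbers stand for a stronger effect at the one dose given and lower numbers for a weaker effect:

compound 1 `NC(=O)CC[C@H](NC(=O)CN(c1ncnc2c1ncn2C1CCCCO1)C1CC1)C(=O)OCc1ccccc1` gives 39.4%
compound 2 `O=C(CN(c1ncnc2c1ncn2C1CCCCO1)C1CC1)N[C@@H](CC(=O)OCc1ccccc1)C(=O)OCc1ccccc1` gives 38.2%
compound 3 `N=C(N)NCCC[C@H](NC(=O)CN(c1ncnc2c1ncn2C1CCCCO1)C1CC1)C(=O)OCc1ccccc1` gives 52.4%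

Compound 3 stands highest of the three, with compound 1 beyond the scatter below it, as the step of a number 13 percentage points higher from compound 1 to compound 3 (beyond the scatter) shows, and compound 2 furthest away, as the step of a number 14.2 percentage points higher from compound 2 to compound 3 (beyond the scatter) shows. Compound 1 and compound 2 lie within the scatter of each other, the step being a number 1.2 percentage points lower from compound 1 to compound 2 (within the scatter).

Compound 4 `CSCC[C@H](NC(=O)CN(c1ncnc2c1ncn2C1CCCCO1)C1CC1)C(=O)OCc1ccccc1` differs from compound 3 in one place: a group of 2 heavy atoms (1 carbon, 1 sulfur; no ring) in place of a group of 5 heavy atoms (2 carbon, 3 nitrogen; no ring), on a saturated chain carbon, three bonds along the chain from an amide-type nitrogen and a carbonyl carbon. For the measured compounds named here, the step that bears on it is a number 13 percentage points higher from compound 1 to compound 3 (beyond the scatter), which added the same group of 5 heavy atoms that now leaves and was modest in size; compound 4 instead carries methylsulfanyl, for which no measured step exists. The expectation is therefore a modest fall from compound 3, roughly undoing that gain, and compound 4 is expected to come out near compound 1, with a number 12.4 percentage points lower from compound 3 to compound 4 (beyond the scatter) as the estimated step. Compound 4 is estimated at 40%, within a range from 28% to 52%.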

Compound 4, a percentage reported as activity, at one dose (the size of the read-out at that dose, not a potency): 41%
Compound 4: the middle estimate sits 1 percentage points below what was measured; the range from low to high includes it.
By their numbers in this assay, from the lowest: compounds 2, 1 and 4 (each within the scatter of the next); then compound 3.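

In this assay, putting methylsulfanyl at this position, three bonds along the chain from an amide-type nitrogen and a carbonyl carbon, removes the group of 5 heavy atoms (2 carbon, 3 nitrogen) and loses the higher number (a number 11.4 percentage points lower from compound 3 to compound 4 (beyond the scatter)). The result is not separable from either carbamoyl (a number 1.6 percentage points higher from compound 1 to compound 4 (within the scatter)) or benzyloxycarbonyl (a number 2.8 percentage points higher from compound 2 to compound 4 (within the scatter)), so three quite different groups now read alike, and among the compounds shown only the group of 5 heavy atoms stands apart. Nothing measured here accounts for this result.

As far as these compounds go, whether an amine or a carboxylic acid at the chain end would match that group remains open, as does the effect of a longer chain carrying it. The read-out also comes from a single dose, so it leaves potency unsettled.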